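A few compounds are considered here, and "the series" means these few. Any claim that something is new, unique, unknown or untested is made for them only; others in the source may bear on it.

In a functional assay on MCF7 cells (Homo sapiens) for inhibition, read by sulforhodamine B assay, with a stated time of 48 h (on this read-out lower numbers stand for stronger inhibition of growth and higher numbers for weaker inhibition of growth), compound 2 `COc1ccc2[nH]c(-c3ccccc3)c(/C=C(\C#N)S(=O)(=O)c3ccccc3)c2c1` gives 3900 nM, the higher of the two numbers in hand. Compound 1 `CC(=O)/C(=C\c1c(-c2ccccc2)[nH]c2ccccc12)S(=O)(=O)c1ccccc1` gives 945 nM in this assay, yet it differs from compound 2 in more than one place, so that gap cannot be tied to one change. Compound 3 `N#C/C(=C\c1c(-c2ccccc2)[nH]c2ccccc12)S(=O)(=O)c1ccccc1` differs from compound 2 by hydrogen in place of methoxy on an aromatic carbon. Among the measured compounds shown here, no measured pair isolates this change, so only a small step, expected to lean toward stronger inhibition, is assumed: a 2.2-fold lower number from compound 2 to compound 3 (0.34 log units; beyond the scatter). Compound 3 is estimated at 1800 nM, within 500 nM to 6000 nM.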

Compound 3, concentration for 50% growth inhibition: 2200 nM
Estimate against measurement, compound 3: 1.2-fold (0.09 log units) below; measured number inside the range.
By their numbers in this assay, from the lowest: compound 1; then compounds 3 and 2 (each within the scatter of the next).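

In this assay, hydrogen in place of methoxy on the aromatic carbon gives a 1.8-fold lower number from compound 2 to compound 3 (0.25 log units; within the scatter), so at this position the two groups cannot be told apart on this read-out. Cyano in place of acetyl on the double-bonded chain carbon gives a 2.3-fold higher number from compound 1 to compound 3 (0.37 log units; beyond the scatter), a modest step that favours acetyl and is the first change isolated here to reach beyond the scatter. No measurement at hand explains either step. Going by these compounds, it remains open whether an amine on that aromatic carbon would change growth inhibition. A carboxylic acid or a longer chain in place of acetyl is equally untested by these compounds.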